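Dropping a Bromo Substituent in a Cytotoxicity Series

The source may report more compounds than this note shows. Statements on the series, on what has been measured and on what is new or still open speak of the compounds shown alone.

Measured compounds:
compound 1, `COc1ccc2c(c1)c(/C=N\NC(=O)c1c[nH]c3ccc(Br)cc13)cn2Cc1ccc(Cl)cc1`: 5000 nM
compound 2, `COc1ccc(Cn2cc(/C=N\NC(=O)c3c[nH]c4ccccc34)c3ccccc32)cc1`: 15100 nM
compound 3, `Cn1cc(C(=O)N/N=C\c2cn(Cc3ccc(Cl)cc3)c3cc(F)ccc23)c2ccccc21`: > 100000 nM, which is a limit of the assay and not a number

In a functional assay on MDA-MB-231 cells (Homo sapiens) for cytotoxicity (on this read-out higher numbers stand for weaker inhibition and lower numbers for stronger inhibition), compound 1 holds the lowest of the two numbers reported. Compound 2 gives a number that sits higher, and that gap lies beyond the usual scatter of repeated measurements. Within the data shown here, for compound 3 the assay returns only a limit; the limit of > 100000 nM in this assay, at which 1 of the 3 values shown sits, is the only such reading among the three.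

The unmeasured compound 4, `COc1ccc2c(c1)c(/C=N\NC(=O)c1c[nH]c3ccccc13)cn2Cc1ccc(Cl)cc1`, differs from compound 1 in a single place: hydrogen in place of bromo on an aromatic carbon. Among the measured compounds shown here, no pair of measured compounds isolates this change, so no measured step shows what it does on its own. With only a bromo substituent departing and hydrogen entering, the step in this assay is expected to be small, most likely toward a somewhat higher number, and quite possibly not beyond the scatter at all.

Compound 4 is therefore expected to give 8000 nM, with a plausible range from 3000 nM to 25000 nM. The expected step of a 1.6-fold higher number from compound 1 to compound 4 (0.20 log units; within the scatter) is modest, a loss rather than a gain, and it should not push compound 4 to the limit that compound 3 reached.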

Compound 4, half-maximal inhibitory concentration: 82700 nM
Estimate against measurement, compound 4: 10-fold (1.01 log units) below; the whole stated range lies below it.
By their numbers in this assay, from the lowest: compound 1; then compound 2; then compound 4. At a limit, above all of these: compound 3.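

In this assay the removal of bromo from this aromatic carbon, the change from 5-bromo-1H-indol-3-yl to 1H-indol-3-yl, is a 17-fold higher number from compound 1 to compound 4 (1.22 log units; beyond the scatter) and is large, so a single heavy atom at this position carries much of the inhibition that compound 1 shows. The earlier compounds shown here could not show this, as no two of them differ in one place only, and the position had no measured step of its own until compound 4 supplied one. The step gives the size of the change and its direction on this one background, but nothing measured here accounts for why a single atom matters this much.

From the compounds shown here alone, whether the effect belongs to bromine in particular, or whether iodo, a methyl group or a nitrile on the same aromatic carbon would hold the lower number of compound 1, stays open. Also open is whether the step carries over to other substitution on the rest of the molecule, since compound 1 is the only compound shown with bromo and the change can be read only once.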